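The source may hold more compounds than are shown below. What is called first, only, known or untested is meant among the compounds shown, and "the series" means these compounds.

Measured so far in a functional assay on NUGC-3 cells (Homo sapiens) for antiproliferative activity, read by sulforhodamine B assay; a lower number here means a stronger inhibitor of growth, a higher number a weaker inhibitor of growth:
compound 1 `CC1(C)CC(=O)c2s/c(=N/c3ccc(Cl)cc3)oc2C1` gives 2940 nM.
compound 2 `CC1CC(=O)c2s/c(=N/c3ccc(Cl)cc3)oc2C1` gives 15900 nM.
compound 3 `CC1(C)CC(=O)c2s/c(=N/c3c(Cl)cc(Cl)cc3Cl)oc2C1` reaches only a limit of this assay, > 30000 nM.

Compound 1 and compound 2 share one core and differ in one place, (hydrogen in place of methyl on a saturated ring carbon). That step in this assay is a 5.4-fold higher number from compound 1 to compound 2 (0.73 log units; beyond the scatter). Between compound 1 and compound 3 the difference between the two cores is not broken down here. Compound 3 sits at the limit of > 30000 nM in this assay, at which 1 of the 3 values shown sits, so only a limit is known for it.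

Compound 4 `CC1CC(=O)c2s/c(=N/c3c(Cl)cc(Cl)cc3Cl)oc2C1` is not yet measured. It stands to compound 3 as compound 2 stands to compound 1: hydrogen in place of methyl on a saturated ring carbon, the same change at the same kind of place, the second time this change occurs in the set. Starting from a compound that already reports only a limit, the same change is expected to move the number further in the same direction, by a step that the limit leaves unreadable from compound 3 to compound 4. This expectation rests on the measured step of a 5.4-fold higher number from compound 1 to compound 2 (0.73 log units; beyond the scatter). Compound 4 is therefore expected near 80000 nM, in the range 30000 nM to 300000 nM, most likely returned again only as a limit of this assay rather than as a number.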

Compound 4, concentration for 50% growth inhibition: > 30000 nM
Compound 4: no number, only a limit; the forecaster's own chance of this, stated with the estimate: 90%; the middle value lies beyond the limit too.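

Compound 3 and compound 4 both return only a limit in this assay, so no step between them can be read: the limit of > 30000 nM in this assay, at which 2 of the 4 values shown sit.

The compounds shown leave open how far beyond that limit compound 3 and compound 4 lie, and whether hydrogen in place of methyl on a saturated ring carbon changes the number on the core of compound 3 as it does on the core of compound 1.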